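Replacing vinyl in compound 3

This account rests on a few compounds, and the source may have more. Where it says the series, first, only, none or still open, it means among the compounds named here.

In a functional assay on A549 cells (Homo sapiens) for antiproliferative activity, read by MTT assay, with a stated time of 72 h (on this read-out lower numbers stand for stronger inhibition and higher numbers for weaker inhibition), compound 3 `C=CC(=O)Nc1cccc(Oc2nc(Nc3cccc(C#N)c3)nc3c2CSCC3)c1` gives 6860 nM, within the scatter of compound 1 `C=CC(=O)Nc1cccc(Oc2nc(Nc3cccc(OC)c3)nc3c2CSCC3)c1` at 10100 nM. Compound 2 `COc1cccc(Nc2nc3c(c(Oc4cccc(NC(=O)C=C(C)C)c4)n2)CSCC3)c1` gives 19800 nM. Among the compounds with values here, that number is higher than the one of compound 3, and the gap lies beyond the scatter.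

Compound 4 `CC(C)=CC(=O)Nc1cccc(Oc2nc(Nc3cccc(C#N)c3)nc3c2CSCC3)c1` differs from compound 3 by 2-methylprop-1-en-1-yl in place of vinyl on a carbonyl carbon. The same change was measured once, as a 2.0-fold higher number from compound 1 to compound 2 (0.29 log units; within the scatter). The cyano in place of methoxy change, seen as a 1.5-fold lower number from compound 1 to compound 3 (0.17 log units; within the scatter), also stayed within the scatter, so a similar upward step seems reasonable on the cyano compound. The expected step is a 2.0-fold higher number from compound 3 to compound 4 (0.29 log units; within the scatter), near the edge of the scatter. Compound 4 is estimated at 13500 nM, with an expected range of 6500 nM to 28000 nM.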

Compound 4, half-maximal inhibitory concentration: 36900 nM
For compound 4 the middle estimate is 2.7-fold (0.44 log units) below the measured one, and the stated range ends below it.
By their numbers in this assay, from the lowest: compounds 3, 1, 2 and 4 (each within the scatter of the next, the first and the last beyond it).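

On the cyano compound, 2-methylprop-1-en-1-yl in place of vinyl on the carbonyl carbon gives a 5.4-fold higher number from compound 3 to compound 4 (0.73 log units; beyond the scatter) in this assay. This is the first step for this change that clears the scatter, and its size depends on the core: the same change on two cores in this assay, a 2.0-fold higher number (0.29 log units; within the scatter) from compound 1 to compound 2 and a 5.4-fold higher number (0.73 log units; beyond the scatter) from compound 3 to compound 4, 2.7-fold (0.44 log units) apart, beyond the scatter of two such steps

With 2-methylprop-1-en-1-yl in place, cyano in place of methoxy gives a 1.9-fold higher number from compound 2 to compound 4 (0.27 log units; within the scatter), so that change also reads differently on the two cores: the same change on two cores in this assay, a 1.5-fold lower number (0.17 log units; within the scatter) from compound 1 to compound 3 and a 1.9-fold higher number (0.27 log units; within the scatter) from compound 2 to compound 4, 2.7-fold (0.44 log units) apart, beyond the scatter of two such steps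

Still open, as far as these compounds go, is how an amine or a longer unbranched chain on the carbonyl carbon would read in this assay, and whether the larger step would recur on a third core.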